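A few compounds are considered here, and "the series" means these few. Any claim that something is new, unique, unknown or untested is made for them only; others in the source may bear on it.

Measured in an assay on HEK293 cells for inhibition of Nitric oxide synthase, inducible (Homo sapiens), with a stated time of 18 h; on this read-out lower numbers stand for an effect already at smaller amounts and higher numbers for an effect only at larger amounts of compound:
compound 1 `CN(CCCNCc1ccc2c(c1)OCCO2)c1nc(-n2ccnc2)ns1`: 48 nM
compound 2 `COc1ccc(CNCCCN(C)c2nc(-n3ccnc3)ns2)cc1`: 360 nM

Compound 2 stands at the highest of the two numbers; compound 1 sits well below it, and that gap lies beyond the scatter. Compound 3 `COc1ccc(CNCCCN(C)c2nc(-n3ccnc3)ns2)cc1OC` differs from compound 2 by methoxy in place of hydrogen on an aromatic carbon. For the measured compounds named here, no measured pair shows this exact step, so the expectation rests on the two values alone. Compound 1, with 48 nM, is the nearer structural analogue, so a modest downward move is expected rather than none. For compound 3 the step of a 2.4-fold lower number from compound 2 to compound 3 (0.38 log units; beyond the scatter) is expected. Compound 3 is estimated at 150 nM, with a range from 50 nM to 450 nM.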

Compound 3, half-maximal effective concentration: 760 nM
Compound 3: middle estimate off by 5.1-fold (0.70 log units), on the low side, and the stated range ends below it.
By their numbers in this assay, from the lowest: compound 1; then compound 2; then compound 3.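

In this assay, for the compounds shown here, methoxy in place of hydrogen on an aromatic carbon, ortho to a methoxy group and meta to a large group, gives a 2.1-fold higher number from compound 2 to compound 3 (0.32 log units; beyond the scatter) as the first single-place step. This position is therefore not neutral to the added methoxy, and the number moves upward there. Nothing measured here accounts for the step. Going by these compounds, whether the rise is specific to methoxy stays open. Fluorine, a hydroxyl or an amine on the same carbon would test that.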